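Carbamoylpyridinyl oxazole ketone: expected inhibition from two methylpyridinyl analogues

A few compounds are considered here, and "the series" means these few. Any claim that something is new, unique, unknown or untested is made for them only; others in the source may bear on it.

Compound 1 `Cc1ccnc(-c2cnc(C(=O)CCCCCCc3ccccc3)o2)c1` and compound 2 `Cc1cccc(-c2cnc(C(=O)CCCCCCc3ccccc3)o2)n1` share the same core and differ only in where the methyl sits on the pyridinyl ring. In an assay (Rattus norvegicus) for inhibition of Fatty-acid amide hydrolase 1 (Homo sapiens) (a higher number here means a weaker inhibitor, a lower number a stronger inhibitor), compound 1 gives 0.6 nM, and compound 2 gives 3.3 nM, the higher of the two numbers; the step of a 5.5-fold higher number from compound 1 to compound 2 (0.74 log units; beyond the scatter) is modest but beyond the scatter. Compound 3 `NC(=O)c1ccc(-c2cnc(C(=O)CCCCCCc3ccccc3)o2)nc1` is not yet measured; the change from compound 2 is 5-carbamoylpyridin-2-yl in place of 6-methylpyridin-2-yl on an aromatic carbon. Among the compounds with values here, no measured step bears on this change directly: the only step on record, from compound 1 to compound 2, concerns a shift of the methyl and not its replacement by a carbamoyl group. Within the data shown here, compound 3 is therefore estimated at 1.5 nM in this assay, with a range of 0.3 nM to 8 nM, because compound 2 gives 3.3 nM and the series so far stays in this narrow band. The expected step is a 2.2-fold lower number from compound 2 to compound 3 (0.34 log units; beyond the scatter), towards a somewhat lower number, but within uncertainty that could also be no change beyond the scatter.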

Compound 3, inhibition constant: 1.2 nM
For compound 3 the middle estimate is 1.3-fold (0.10 log units) above the measured one; the measured number falls inside the stated range.
By their numbers in this assay, from the lowest: compounds 1 and 3 (each within the scatter of the next); then compound 2.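

In this assay the exchange of 6-methylpyridin-2-yl for 5-carbamoylpyridin-2-yl on this aromatic carbon gives a 2.8-fold lower number from compound 2 to compound 3 (0.44 log units; beyond the scatter) and so shows that this position tolerates a larger pyridinyl group carrying a hydrogen-bond donor, not only a methylpyridinyl one. Exchanging the 4-methylpyridin-2-yl of compound 1 for the same group gives a 2.0-fold higher number from compound 1 to compound 3 (0.30 log units; within the scatter) and leaves these two compounds indistinguishable, so compound 2 alone stands apart in this set of three. Nothing on hand accounts for either step.

The exchange from compound 2 alters both the substituent and its place on the pyridine, and the compounds shown do not separate these two changes. Also open, as far as these compounds go, is how a carboxylic acid, a nitrile or an amine in place of the carbamoyl group would compare.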